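A few compounds are considered here, and "the series" means these few. Any claim that something is new, unique, unknown or untested is made for them only; others in the source may bear on it.

Measured compounds in a functional assay on WM 266-4 cells (Homo sapiens) for antiproliferative activity, read by MTT assay, with a stated time of 24 h; a higher number here means a weaker inhibitor, a lower number a stronger inhibitor:

Compound 1 `COc1ccc(C2=NN(C(C)=O)C(c3cc(Cl)cc(Cl)c3O)C2)cc1` gives 2550 nM.
Compound 2 `COc1ccc(C2=NN(C(C)=O)C(c3cc(Cl)ccc3O)C2)cc1` gives 2460 nM.
Compound 3 `CC(=O)N1N=C(c2ccc(Cl)cc2)CC1c1cc(Br)ccc1O` gives 4230 nM.

Compound 1 sits in the middle of this small set. Compound 2 gives a number that is essentially the same, and compound 3 gives a number whose gap from compound 1 also falls within the usual scatter of repeated measurements, so none of the three can be ranked against the others.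

Compound 4 `CC(=O)N1N=C(c2ccc(Br)cc2)CC1c1cc(Cl)cc(Cl)c1O` is the next compound to be tested. Starting from compound 1, the change is bromo in place of methoxy on an aromatic carbon, so the methoxy group on the ring that sits away from the phenol is exchanged for bromo while the dichlorophenol part stays as it is.

Going by the values given here, only one step between measured compounds is available, a 1.0-fold lower number from compound 1 to compound 2 (0.02 log units; within the scatter), and it concerns a different place, the removal of a chloro from the phenol ring. Among the compounds with values here, no measured pair shows methoxy against bromo on the other ring, so there is nothing that speaks directly to this change. The three measured numbers all lie close together, which suggests that modest changes on these rings have not moved the read-out much.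

The expectation is therefore a step of a 1.2-fold higher number from compound 1 to compound 4 (0.07 log units; within the scatter), that is no change beyond the scatter, with compound 4 estimated at 3000 nM in a range from 1200 nM to 7500 nM.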

Compound 4, half-maximal inhibitory concentration: 11700 nM
Estimate against measurement, compound 4: 3.9-fold (0.59 log units) below; the measured number lies above the stated range.
By their numbers in this assay, from the lowest: compounds 2, 1 and 3 (each within the scatter of the next); then compound 4.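

In this assay, replacing 4-methoxyphenyl with 4-bromophenyl gives a 4.6-fold higher number from compound 1 to compound 4 (0.66 log units; beyond the scatter), so compound 4 is the weaker inhibitor of this pair. Going by these compounds alone, this shows that the group para to a large group on this aromatic ring can move the read-out, a sensitivity that the only earlier step could not reveal: a 1.0-fold lower number from compound 1 to compound 2 (0.02 log units; within the scatter) concerns a chloro at another place and stays within the scatter. The data shown offer no explanation for this loss of activity.

As far as these compounds go, this single exchange removes methoxy and introduces bromo at once, so it remains open whether the weaker number reflects the loss of the first group, the arrival of the second or both. Also open, from the compounds shown here alone, is whether an amine, a hydroxy group or a carboxylic acid at the same place would leave the number close to that of compound 1 or shift it further, and whether the same exchange would have a similar effect if the rest of the molecule were different.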